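A Smaller Triazole Substituent on a Shared Lactone Core

The compounds below may be only part of what the source reports. "The series", "measured", "known", "first", "only" and "open" are said of these compounds alone.

Compound 1 `O=C1O[C@H]([C@@H](O)Cn2cc(CNS(=O)(=O)c3ccc(Cl)cc3F)nn2)C(OCc2ccccc2)=C1OCc1ccccc1` carries a ((4-chloro-2-fluorophenyl)sulfonyl)amino group on a saturated chain carbon bound to an aromatic carbon. In a functional assay on HCT-116 cells (Homo sapiens) for antiproliferative activity, read by MTT assay, with a stated time of 72 h (a higher number here means a weaker inhibitor, a lower number a stronger inhibitor), compound 1 gives 21600 nM. Compound 2 `O=C1O[C@H]([C@@H](O)Cn2cc(-c3cc(C(F)(F)F)cc(C(F)(F)F)c3)nn2)C(OCc2ccccc2)=C1OCc1ccccc1` gives 57200 nM in this assay, so compound 1 stands lowest of the two numbers recorded, and its gap to compound 2 lies beyond the usual scatter. Compound 3 `COc1ccccc1-c1cn(C/C=C2\OC(=O)C(OCc3ccccc3)=C2OCc2ccccc2)nn1` reaches only a limit in this assay, namely > 100000 nM, and this is the limit of > 100000 nM in this assay, at which 1 of the 3 values shown sits.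

Compound 4 `O=C1O[C@H]([C@@H](O)Cn2cc(CCCCl)nn2)C(OCc2ccccc2)=C1OCc1ccccc1` has not yet been measured. It differs from compound 1 in a single place: 2-chloroethyl in place of ((4-chloro-2-fluorophenyl)sulfonyl)amino on a saturated chain carbon bound to an aromatic carbon. Going by the values given here, no step between two measured compounds that differ in one place is available, so the size of this change can only be anticipated. With compound 1 already giving 21600 nM, and with the whole series weak in this assay, the account expects the step of a 2.1-fold higher number from compound 1 to compound 4 (0.32 log units; beyond the scatter) to be a moderate rise, beyond the scatter but not so large that a number is certain to be lost. For compound 4 the estimate is therefore 45000 nM, expected to fall between 15000 nM and 150000 nM.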

Compound 4, half-maximal inhibitory concentration: 36100 nM
Estimate against measurement, compound 4: 1.2-fold (0.10 log units) above; measured number inside the range.
By their numbers in this assay, from the lowest: compounds 1, 4 and 2 (each within the scatter of the next, the first and the last beyond it). At a limit, above all of these: compound 3.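

The exchange of ((4-chloro-2-fluorophenyl)sulfonyl)amino for 2-chloroethyl, on a saturated chain carbon bound to an aromatic carbon, gives a 1.7-fold higher number from compound 1 to compound 4 (0.22 log units; within the scatter) in this assay. Going by these compounds alone, this is the first reading of a single change at this position, and it shows that the two compounds cannot be told apart here, even though the leaving group has 12 heavy atoms, a six-membered aromatic ring, a hydrogen-bond donor and hydrogen-bond acceptors, while the entering group has 3 heavy atoms, no ring, and neither donors nor acceptors. Nothing measured here speaks to a cause for this result.

Going by these compounds, it remains open whether an amine, a carboxylic acid or a longer chain at the same place would give a number that differs beyond the scatter from those of compound 1 and compound 4. Also open, on these data alone, is what the chlorine of 2-chloroethyl contributes, a question that a plain ethyl group at this place would address.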